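The source may report more compounds than this note shows. Statements on the series, on what has been measured and on what is new or still open speak of the compounds shown alone.

In a functional assay on A2780 cells (Homo sapiens) for inhibition (a lower number here means a stronger inhibitor, a higher number a weaker inhibitor), three compounds with the same core have been measured:

- Compound 1 `CC(C(=O)Nc1cc(C2CC2)[nH]n1)c1ccc(N2CCC(C(N)=O)C2=O)cc1`: 5710 nM
- Compound 2 `CC(C(=O)Nc1cc(C2CC2)[nH]n1)c1ccc(N2CCNC2=O)cc1`: 2250 nM
- Compound 3 `CC(C(=O)Nc1cc(C2CC2)[nH]n1)c1ccc(N2CCCC2)cc1`: 370 nM

Compound 3 has the lowest number of the three, which makes it the strongest inhibitor so far. Compound 4 `CC(C(=O)Nc1cc(C2CC2)[nH]n1)c1ccc(-n2ccnc2O)cc1` keeps the core of compound 3 and changes one group, on an aromatic carbon of a six-membered aromatic ring of carbon only, para to a large group: a group of 6 heavy atoms (3 carbon, 2 nitrogen, 1 oxygen; one five-membered aromatic ring with 2 hetero atoms) in place of a group of 5 heavy atoms (4 carbon, 1 nitrogen; one five-membered non-aromatic ring with 1 hetero atom), on an aromatic carbon.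

The closest guide is a 6.1-fold lower number from compound 2 to compound 3 (0.78 log units; beyond the scatter), where pyrrolidin-1-yl replaced 2-oxoimidazolidin-1-yl. The ring entering compound 4 contains the same kinds of atoms as that 2-oxoimidazolidin-1-yl, but it is aromatic. The larger 15-fold lower number from compound 1 to compound 3 (1.19 log units; beyond the scatter) also ends at pyrrolidin-1-yl with a lower number, and a 2.5-fold lower number from compound 1 to compound 2 (0.40 log units; beyond the scatter) shows that the two groups holding oxygen differ from each other too. Among these three compounds, the one without oxygen in this group has the lowest number, and none goes against that. For the measured compounds named here, no aromatic ring has yet been measured here, so the uncertainty is wide.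

A modest move back towards weaker inhibition is expected, estimated as a 4.1-fold higher number from compound 3 to compound 4 (0.61 log units; beyond the scatter). For compound 4 the estimated value is 1500 nM, with an expected range from 500 nM to 4500 nM.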

Compound 4, half-maximal inhibitory concentration: 6980 nM
Estimate against measurement, compound 4: 4.7-fold (0.67 log units) below, and the stated range ends below it.
By their numbers in this assay, from the lowest: compound 3; then compound 2; then compounds 1 and 4 (each within the scatter of the next).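

In this assay, putting the aromatic ring that holds oxygen in place of pyrrolidin-1-yl gives a 19-fold higher number from compound 3 to compound 4 (1.28 log units; beyond the scatter), and so among these four compounds, all sharing one core, each group that holds oxygen has a clearly higher number than the oxygen-free group of compound 3, with none going against this. An aromatic ring therefore does not bring back the strength lost by the non-aromatic groups holding oxygen: a 3.1-fold higher number from compound 2 to compound 4 (0.49 log units; beyond the scatter) separates two groups with the same counts of carbon, nitrogen and oxygen, while a 1.2-fold higher number from compound 1 to compound 4 (0.09 log units; within the scatter) leaves two quite differently sized groups that cannot be told apart in this assay. No measurement at hand explains these differences.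

On these data alone, what remains open is whether the oxygen, the aromatic ring or both account for the high number of compound 4, a question that plain imidazol-1-yl, which has no oxygen, or an open-chain dimethylamino group at this position could help to separate. As far as these compounds go, it is also open whether this order of groups would hold if another part of the shared core were changed.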